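The source may report more compounds than this note shows. Statements on the series, on what has been measured and on what is new or still open speak of the compounds shown alone.

Compound 1 `O=C(/C=C/C(=O)N1C/C(=C\c2ccccc2)C(=O)/C(=C/c2ccccc2)C1)Nc1ccc([N+](=O)[O-])cc1` gives 31000 nM in a functional assay on Molt4/C8 cells (Homo sapiens) for cytotoxicity; a lower number here means a stronger inhibitor, a higher number a weaker inhibitor; compound 2 `O=C(/C=C/C(=O)N1C/C(=C\c2ccc([N+](=O)[O-])cc2)C(=O)/C(=C/c2ccc([N+](=O)[O-])cc2)C1)Nc1ccc([N+](=O)[O-])cc1` gives 430 nM; compound 3 `Cc1ccc(NC(=O)/C=C/C(=O)N2C/C(=C\c3ccccc3)C(=O)/C(=C/c3ccccc3)C2)cc1` gives 660 nM.

Within the data shown here, compound 3 stands second of the three numbers, close to compound 2 and far from compound 1; the only single-point step, a 47-fold lower number from compound 1 to compound 3 (1.67 log units; beyond the scatter), is large. Compound 4 `O=C(/C=C/C(=O)N1C/C(=C\c2ccccc2)C(=O)/C(=C/c2ccccc2)C1)Nc1ccccc1` differs from compound 3 by hydrogen in place of methyl on an aromatic carbon. Among the measured compounds shown here, no measured step trades methyl for hydrogen at this position, so the expectation rests on the large step from compound 1 to compound 3, which shows that this position carries weight, and on the smaller size of the present change. A modest weakening is expected, a 2.3-fold higher number from compound 3 to compound 4 (0.36 log units; beyond the scatter), and compound 4 is estimated at 1500 nM, between 400 nM and 6000 nM.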

Compound 4, half-maximal inhibitory concentration: 520 nM
For compound 4 the middle estimate is 2.9-fold (0.46 log units) above the measured one, within the range that was stated.
By their numbers in this assay, from the lowest: compounds 2, 4 and 3 (each within the scatter of the next); then compound 1.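

In this assay, among these compounds, hydrogen in place of methyl on this aromatic carbon gives a 1.3-fold lower number from compound 3 to compound 4 (0.10 log units; within the scatter) and so leaves the number unmoved, which the earlier compounds could not show. Hydrogen in place of nitro gives a 60-fold lower number from compound 1 to compound 4 (1.78 log units; beyond the scatter) and so places the large gap at the nitro group of compound 1, while methyl and hydrogen read alike here. No measured evidence bears on the reason for this. The compounds shown leave open whether an amine or a carboxylic acid on this carbon would read like compound 4 or like compound 1.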